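The compounds below may be only part of what the source reports. "The series", "measured", "known", "first", "only" and "open" are said of these compounds alone.

Within the data shown here, compound 2, with the structure `COc1cc2c(cc1C(C)NCc1ccccc1)CCC(C)(C)O2`, is one of two compounds measured in an ADME assay on L6 cells (Rattus norvegicus) for cytotoxicity; a higher number here means a weaker inhibitor, a lower number a stronger inhibitor. In this assay compound 2 gives 15300 nM. Compound 1, with the structure `COc1cc2c(cc1C(C)N(C)CCCc1ccccc1)C=CC(C)(C)O2`, is the only companion, and in this assay compound 1 gives 16300 nM. The two numbers lie within the usual scatter of each other, so neither compound can be called the stronger or weaker inhibitor on this evidence; compound 2 simply stands level with compound 1.

Compound 3, with the structure `CCCCNC(C)c1cc2c(cc1OC)OC(C)(C)CC2`, has not yet been measured in this assay. It differs from compound 2 in one place: propyl in place of phenyl on a saturated chain carbon bound to an amine nitrogen. Among the measured compounds shown here, no measured pair shows the effect of this change, so nothing beyond the structures themselves guides the expectation. Because compound 1 gives 16300 nM and compound 2 gives 15300 nM in spite of their own differences, a small step is expected here too. The step in this assay is estimated at a 1.2-fold higher number from compound 2 to compound 3 (0.07 log units; within the scatter), that is, none beyond the scatter. Compound 3 is therefore expected to give about 18000 nM in this assay, within a range from 8000 nM to 40000 nM.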

Compound 3, half-maximal inhibitory concentration: 59000 nM
Estimate against measurement, compound 3: 3.3-fold (0.52 log units) below, outside the stated range (above it).
By their numbers in this assay, from the lowest: compounds 2 and 1 (each within the scatter of the next); then compound 3.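

The group on a saturated chain carbon bound to an amine nitrogen matters in this assay: putting propyl in place of phenyl there gives a 3.9-fold higher number from compound 2 to compound 3 (0.59 log units; beyond the scatter) and makes compound 3 the weaker inhibitor of this pair. Among these compounds, this is the first single change that can be read, as compounds 1 and 2 differ in more than one place and their near-equal values could not show what any one group contributes. The step is modest, and nothing measured alongside it offers an explanation for it.

This one swap changes two things at once, removing the aromatic ring and leaving a smaller group with no ring, so the compounds shown cannot tell which of the two goes with the weaker inhibition. A cyclohexyl group at the same place would keep a ring of carbon without its aromatic character, while a hexyl chain would keep the carbon count without any ring, and these would pull the two apart.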